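Swapping a Sulfonyl for a Benzoyl on the Ring Nitrogen

The source may report more compounds than this note shows. Statements on the series, on what has been measured and on what is new or still open speak of the compounds shown alone.

Compound 1, `O=C1COCCN1c1ccc(/N=C\c2c[nH]c3ccccc23)cc1`, gives 89.1% in a functional assay on BV-2 cells (Mus musculus) for inhibition, read by ELISA, tested at 20 uM; on this read-out lower numbers stand for a stronger effect and higher numbers for a weaker effect at the one concentration tested.
Compound 2, `Cc1ccc(S(=O)(=O)n2cc(/C=N\c3ccc(N4CCOCC4=O)cc3)c3ccccc32)cc1`, gives 94.8% in this assay.

Both numbers are high, meaning a weak effect at the single concentration tested. Within the data shown here, compound 2 holds the top of the two numbers, but its only neighbour is compound 1, and the step of a number 5.7 percentage points higher from compound 1 to compound 2 (within the scatter) falls within the scatter, so the two compounds cannot be told apart on this evidence.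

Compound 3, `O=C1COCCN1c1ccc(/N=C\c2cn(C(=O)c3ccccc3)c3ccccc23)cc1`, differs from compound 2 in one place: benzoyl in place of (4-methylphenyl)sulfonyl on an aromatic nitrogen. Among the measured compounds shown here, the only measured step that bears on this position is the one from compound 1 to compound 2, where a large group entered on the same aromatic nitrogen and the read-out moved by a number 5.7 percentage points higher from compound 1 to compound 2 (within the scatter). Exchanging one large group for another at the same place is therefore expected to produce no step beyond the scatter in this assay, that is, an expected step of a number 3.8 percentage points lower from compound 2 to compound 3 (within the scatter). Compound 3 is estimated to give 91%, with a likely range from 80% to 100%.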

Compound 3, a percentage reported as activity, at one concentration (the size of the read-out at that concentration, not a potency): 185%
The estimate for compound 3 lay 94 percentage points below the measured number; measured number above the stated range.
By their numbers in this assay, from the lowest: compounds 1 and 2 (each within the scatter of the next); then compound 3.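

The position on the aromatic nitrogen tolerates one large group without a clear change but responds strongly to another, so "a large group" is too coarse a description of what sits there. In this assay, benzoyl in place of (4-methylphenyl)sulfonyl gives a number 90.2 percentage points higher from compound 2 to compound 3 (beyond the scatter), even though both groups carry one six-membered aromatic ring of carbon only. Benzoyl in place of hydrogen gives a number 95.9 percentage points higher from compound 1 to compound 3 (beyond the scatter), whereas (4-methylphenyl)sulfonyl in place of hydrogen gives only a number 5.7 percentage points higher from compound 1 to compound 2 (within the scatter), so in these three compounds the read-out depends on which group enters and not merely on whether the hydrogen is replaced, and no measurement at hand explains the difference between the two groups.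

With one compound of each kind, these results cannot show whether the jump belongs to the benzoyl group as a whole or to its carbonyl joined to the ring nitrogen. An acetyl group would keep that carbonyl without the aromatic ring, a benzyl group would keep the aromatic ring without the carbonyl, and 4-methylbenzoyl would test whether a methyl on the benzoyl ring changes the picture.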